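Diol stereochemistry in a pancreatic lipase inhibitor series

The source may hold more compounds than are shown below. What is called first, only, known or untested is meant among the compounds shown, and "the series" means these compounds.

Measured so far:
- compound 1 `COc1cc([C@H](O)[C@H](C)O)ccc1O`: 9100 nM
- compound 2 `COc1cc(O)cc([C@@H]2CC(=O)O[C@H]2C)c1`: 65300 nM

Two compounds have numbers in an assay on isolated protein for inhibition of pancreatic triacylglycerol lipase (Sus scrofa), read by ELISA; on this read-out higher numbers stand for weaker inhibition and lower numbers for stronger inhibition. Compound 1 `COc1cc([C@H](O)[C@H](C)O)ccc1O` gives 9100 nM and holds the lowest number of the two; its nearest neighbour is compound 2 `COc1cc(O)cc([C@@H]2CC(=O)O[C@H]2C)c1`, which in this assay gives 65300 nM, a gap that lies beyond the scatter. For the measured compounds named here, no step between the two measured compounds is given, since they differ in more than one place, so nothing can be said about what any single change does.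

The next compound is compound 3 `COc1cc([C@@H](O)[C@H](C)O)ccc1O`, to be measured in this assay. It relates to compound 1 as follows: the two compounds have the same atoms and bonds and differ only in configuration as drawn: 1 of 2 stereo elements differ; a stereocentre at a saturated chain carbon is drawn S in compound 1 and R in compound 3. Going by the values given here, no measured pair shows what a change of configuration at this centre does, so the direction of the step cannot be drawn from the data. The expectation is that the step of a 1.3-fold higher number from compound 1 to compound 3 (0.12 log units; within the scatter) stays near the scatter, with a wide range on either side. Compound 3 is estimated at 12000 nM, between 3000 nM and 45000 nM.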

Compound 3, half-maximal inhibitory concentration: 12100 nM
Beside the measured number, compound 3's estimate is 1.0-fold (0.00 log units) below it, within the range that was stated.
By their numbers in this assay, from the lowest: compounds 1 and 3 (each within the scatter of the next); then compound 2.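

In this assay, for the compounds shown here, inverting the stereocentre at the saturated chain carbon from S to R gives a 1.3-fold higher number from compound 1 to compound 3 (0.12 log units; within the scatter), the first step that can be read at a single position. The step can be assigned to configuration alone, since nothing else separates the pair: the fact that compounds 1 and 3 differ only in the configuration as drawn. This inversion therefore shows no preference for either configuration at this centre, a finding that rests on this one pair and on a background in which the second stereo element stays as drawn.

Going by these compounds, what the second stereo element contributes remains open, as does whether the same lack of preference would hold if both centres were inverted together. It is also unknown how the number would respond if an amine took the place of the hydroxyl group at this centre, or if a longer chain replaced the chain that carries it.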